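The source may report more compounds than this note shows. Statements on the series, on what has been measured and on what is new or still open speak of the compounds shown alone.

Measured so far:
- compound 1 `CC(C)c1ccc(OC/C(=N\NC(N)=S)c2ccc(Br)cc2)cc1` 24600 nM
- compound 2 `NC(=S)N/N=C(\COc1ccccc1Cl)c1ccc(Br)cc1` 25100 nM

In an ADME assay on L929 cells (Mus musculus) for cytotoxicity, read by resazurin assay, with a stated time of 96 h (a lower number here means that less compound is tolerated, a higher number that more compound is tolerated), compound 2 (25100 nM) stands level with compound 1 (24600 nM), as the two values lie within the scatter of each other. Compound 3 `NC(=S)N/N=C(\COc1ccc(Cl)cc1)c1ccc(Br)cc1` has the same atoms as compound 2, joined differently, with 4-chlorophenyl in place of 2-chlorophenyl on an oxygen on a saturated carbon. Compound 1 (24600 nM) also carries a different group on that oxygen, and its value matches that of compound 2 within the scatter. No change beyond the scatter is therefore expected in this assay (a 1.0-fold lower number from compound 2 to compound 3 (0.02 log units; within the scatter)). For compound 3 the estimated value is 24000 nM (expected range 12000 nM to 48000 nM).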

Compound 3, half-maximal cytotoxic concentration: < 25100 nM
Compound 3 ended at the assay's limit; the forecaster's own chance of this, stated with the estimate: 5%; the middle value is on the limit's open side.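

In this assay compound 3 gives < 25100 nM, which is a limit of the assay and not a number. The move from 2-chlorophenyl to 4-chlorophenyl on this oxygen shows a number no higher from compound 2 to compound 3 (the limit leaves the size open), so it gets no size here. The step to compound 3 from compound 1 cannot be read. The reading rests on that limit: the limit of < 25100 nM in this assay, at which 1 of the 3 values shown sits.

The compounds shown leave open how far compound 3 really lies from the other two. They also leave open how an amine or a carboxylic acid in place of 4-chlorophenyl would behave in this assay.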